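Phenyl for Methyl on a Second Core: Expected Inhibition

This account rests on a few compounds, and the source may have more. Where it says the series, first, only, none or still open, it means among the compounds named here.

Compound 1 `Cc1cc2c(c(N)nn2C)c(=O)[nH]1`: 5% in an assay on isolated protein for inhibition of serine/threonine-protein kinase D2 (Homo sapiens), read by mobility shift assay, tested at 30 uM; on this read-out lower numbers stand for less inhibition and higher numbers for more inhibition at the one concentration tested (going by the name of the read-out)
Compound 2 `Cn1nc(N)c2c(=O)[nH]c(-c3ccccc3)cc21`: 14% in this assay
Compound 3 `COCCNc1nc(C)cc2c1c(N)nn2C`: 4% in this assay

All three numbers are small and lie within the scatter of one another, so they give no ground to rank the compounds. Between compound 1 and compound 2 the change is phenyl in place of methyl on an aromatic carbon. That step gave a number 9 percentage points higher from compound 1 to compound 2 (within the scatter).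

Compound 4 `COCCNc1nc(-c2ccccc2)cc2c1c(N)nn2C` has not yet been measured. Its change from compound 3 is phenyl in place of methyl on an aromatic carbon, the same kind of change, though the surroundings differ: here the place is meta to a (2-methoxyethyl)amino group rather than meta to a group of 1 heavy atom. How the cores of compound 1 and compound 3 differ is not broken down here.

Because compound 3 gives 4% and the earlier step gave a number 9 percentage points higher from compound 1 to compound 2 (within the scatter), the expected step is a number 9 percentage points higher from compound 3 to compound 4 (within the scatter). Compound 4 is estimated at 13%, between 0% and 30%.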

Compound 4, a percentage reported as inhibition, at one concentration (the size of the read-out at that concentration, not a potency): 1%
Beside the measured number, compound 4's estimate is 12 percentage points above it, and the stated range covers the measured number.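

Phenyl in place of methyl gave a number 3 percentage points lower from compound 3 to compound 4 (within the scatter), and this step can be set beside the one seen on the core of compound 1: the same change on two cores in this assay, a number 9 percentage points higher (within the scatter) from compound 1 to compound 2 and a number 3 percentage points lower (within the scatter) from compound 3 to compound 4, 12 percentage points apart, within the scatter of two such steps. The two steps therefore cannot be told apart, and neither stands clear of the scatter, so nothing here shows that the change has any effect in this assay on either core. Nor is it shown that the change carries over equally between cores, as a small real difference could stay hidden among numbers this low.

The compounds shown carry only methyl or phenyl at this place, so an amine, a carboxylic acid or a longer chain there remains open. Also open, from the compounds shown here alone, is how the phenyl step would behave with a group other than (2-methoxyethyl)amino on the core.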